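The compounds below may be only part of what the source reports. "The series", "measured", "known", "first", "only" and "open" are said of these compounds alone.

Compound 1 `CCCOC(=O)CCC(=O)N1CCN(CCCOc2cc3c(Nc4ccc(F)c(Cl)c4)ncnc3cc2OC)CC1`: 23.4%
Compound 2 `CCCCCCCCCCCCOC(=O)CCC(=O)N1CCN(CCCOc2cc3c(Nc4ccc(F)c(Cl)c4)ncnc3cc2OC)CC1`: 2.3%

Both were tested in a functional assay on A549 cells (Homo sapiens) for cytotoxicity, read by MTT assay, with a stated time of 24 h, tested at 80 uM; on this read-out lower numbers stand for a stronger effect and higher numbers for a weaker effect at the one concentration tested. Among the measured compounds shown here, compound 2 stands lowest of the two numbers, set apart from its only neighbour by a number 21.1 percentage points lower from compound 1 to compound 2 (beyond the scatter). Compound 3 `CCCCCCCCCCCCCOC(=O)CCC(=O)N1CCN(CCCOc2cc3c(Nc4ccc(F)c(Cl)c4)ncnc3cc2OC)CC1` differs from compound 2 by methyl in place of hydrogen on a saturated chain carbon, ten or more bonds along the chain from an oxygen next to a carbonyl group. For the measured compounds named here, the one measured step that bears on this change is a number 21.1 percentage points lower from compound 1 to compound 2 (beyond the scatter), a modest drop for a far larger lengthening of the same chain. One added carbon is expected to shift the number little, likely not beyond the scatter, so the step to compound 3 is estimated at a number 0.3 percentage points lower from compound 2 to compound 3 (within the scatter). Compound 3 is therefore expected to give about 2%, within 0% to 10%.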

Compound 3, a percentage reported as activity, at one concentration (the size of the read-out at that concentration, not a potency): 6.8%
The estimate for compound 3 lay 4.8 percentage points below the measured number; the measured number falls inside the stated range.
By their numbers in this assay, from the lowest: compounds 2 and 3 (each within the scatter of the next); then compound 1.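

In this assay, methyl in place of hydrogen on a saturated chain carbon gives a number 4.5 percentage points higher from compound 2 to compound 3 (within the scatter), so the two cannot be told apart at this position. The large gap between a short and a long chain persists here, with a number 16.6 percentage points lower from compound 1 to compound 3 (beyond the scatter), and this one added carbon does not alter that picture. Nothing measured here explains either step. From the compounds shown here alone, whether a longer chain would read the same stays open, as does the effect of an amine or a carboxylic acid on this chain.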